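The source may report more compounds than this note shows. Statements on the series, on what has been measured and on what is new or still open speak of the compounds shown alone.

Measured compounds:
- compound 1, `CCCCN(CCC(=O)c1c(CC)nc(CCC)n1Cc1ccc(-c2ccccc2S(=O)(=O)NC(=O)OCCC(C)C)cc1F)C(=O)c1ccccc1`: in an assay on isolated protein for inhibition of Type-2 angiotensin II receptor (Rattus norvegicus) (on this read-out lower numbers stand for stronger inhibition and higher numbers for weaker inhibition), compound 1 gives 10 nM
- compound 2, `CCCc1nc(CC)c(C(=O)CCN(C(=O)c2ccccc2)c2ccccc2)n1Cc1ccc(-c2ccccc2S(=O)(=O)NC(=O)OCCC(C)C)cc1F`: in this assay compound 2 gives 0.18 nM; 0.06 nM (2 entries)
- compound 3, `CCCC(=O)N(CCC(=O)c1c(CC)nc(CCC)n1Cc1ccc(-c2ccccc2S(=O)(=O)NC(=O)OCCC(C)C)cc1F)c1ccccc1`: in this assay compound 3 gives 0.15 nM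

Compound 3 holds the lowest of the two single numbers in this assay; the nearest single number, that of compound 1, is higher by a gap well beyond the scatter. Compound 2 carries no single number, but its repeated entries, (the several entries of compound 2 in this assay, 0.18 nM; 0.06 nM (2 entries)), lie close to the number of compound 3.

Compound 4, `CCCc1nc(CC)c(C(=O)CCN(C(=O)c2ccncc2)c2ccccc2)n1Cc1ccc(-c2ccccc2S(=O)(=O)NC(=O)OCCC(C)C)cc1F`, is to be measured in this assay. It differs from compound 3 in one place: pyridin-4-yl in place of propyl on a carbonyl carbon. Among the measured compounds shown here, no measured step of this kind exists, so the expectation rests on what the near-identical numbers of compound 2 and compound 3 show at this part of the molecule. The expected step from compound 3 to compound 4 is a 1.3-fold higher number from compound 3 to compound 4 (0.12 log units; within the scatter), that is, none beyond the scatter. Compound 4 is estimated at 0.2 nM, within a range from 0.05 nM to 0.8 nM.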

Compound 4, half-maximal inhibitory concentration: 0.1 nM
The estimate for compound 4 lay 2.0-fold (0.30 log units) above the measured number; the range from low to high includes it.
By their numbers in this assay, from the lowest: compounds 4 and 3 (each within the scatter of the next); then compound 1.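

Among the compounds shown here, on the carbonyl carbon whose other neighbour is the amide-type nitrogen, the first measured step in this assay is small: a 1.5-fold lower number from compound 3 to compound 4 (0.18 log units; within the scatter). This place therefore takes pyridin-4-yl, a six-membered aromatic ring with one hetero atom and one hydrogen-bond acceptor, in place of the open propyl chain, with no change beyond the scatter. Compound 2, with phenyl on the same carbonyl carbon, falls in the same low range, so propyl, phenyl and pyridin-4-yl are not told apart at this place: the several entries of compound 2 in this assay, 0.18 nM; 0.06 nM (2 entries)

The compounds shown leave open whether a carboxylic acid, a dimethylamino group or a chain longer than propyl on this carbonyl carbon would stay in this range. They also leave open whether pyridin-4-yl holds its number with butyl on the amide-type nitrogen, as in compound 1, instead of phenyl.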